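Working notes: bromo in place of fluoro

This account rests on a few compounds, and the source may have more. Where it says the series, first, only, none or still open, it means among the compounds named here.

Compound 1 `COC(=O)CNc1cc(NS(=O)(=O)/C=C/c2c(OC)cc(OC)cc2OC)ccc1OC` gives 350 nM
Compound 2 `COc1cc(OC)c(/C=C/S(=O)(=O)Nc2ccc(OC)c(NC(C)C(=O)O)c2)c(OC)c1` gives 8 nM
Compound 3 `COc1cc(OC)c(/C=C/S(=O)(=O)Nc2ccc(OC)c(NC(C(=O)O)c3ccc(F)cc3)c2)c(OC)c1` gives 20 nM

In a functional assay on K562 cells (Homo sapiens) for cytotoxicity, read by trypan blue exclusion, with a stated time of 96 h (a higher number here means a weaker inhibitor, a lower number a stronger inhibitor), compound 3 holds the middle of the three numbers, with compound 2 lower and compound 1 higher. Next comes compound 4 `COc1cc(OC)c(/C=C/S(=O)(=O)Nc2ccc(OC)c(NC(C(=O)O)c3ccc(Br)cc3)c2)c(OC)c1`, which carries bromo in place of fluoro on an aromatic carbon, para to a large group.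

Going by the values given here, no measured pair changes this halogen. The closest evidence is a 2.5-fold higher number from compound 2 to compound 3 (0.40 log units; beyond the scatter), a modest step even though 4-fluorophenyl replaced methyl. The large steps of a 44-fold lower number from compound 1 to compound 2 (1.64 log units; beyond the scatter) and an 18-fold lower number from compound 1 to compound 3 (1.24 log units; beyond the scatter) replace (methoxycarbonyl)methyl and say little about a halogen exchange.

No step beyond the scatter, in either direction, is therefore expected in this assay. The expected change is no change at the digits printed from compound 3 to compound 4 (within the scatter). For compound 4 the estimate is 20 nM, with an expected range from 8 nM to 50 nM.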

Compound 4, half-maximal inhibitory concentration: 75 nM
The estimate for compound 4 lay 3.8-fold (0.57 log units) below the measured number, outside the stated range (above it).
By their numbers in this assay, from the lowest: compound 2; then compound 3; then compound 4; then compound 1.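

In this assay, going by these compounds alone, this aromatic carbon is not indifferent to the halogen: a 3.8-fold higher number from compound 3 to compound 4 (0.57 log units; beyond the scatter), the first measured exchange at this position, and it lies beyond the scatter. The 4-bromophenyl group also widens the gap to the methyl group, with a 9.4-fold higher number from compound 2 to compound 4 (0.97 log units; beyond the scatter), against a 2.5-fold higher number from compound 2 to compound 3 (0.40 log units; beyond the scatter) for 4-fluorophenyl, while the (4-bromophenyl)(carboxy)methyl group still retains an advantage over (methoxycarbonyl)methyl, with a 4.7-fold lower number from compound 1 to compound 4 (0.67 log units; beyond the scatter). No available measurement gives a reason for the shift with this halogen exchange.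

With only fluoro and bromo shown at this carbon, two points cannot establish a trend across substituents. Chloro, iodo or a nitrile at the same place would show whether the number follows the halogen series or whether bromo is a single departure.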